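Replacing a Hydroxy Group: Expected Shift in Acid Dissociation

This account rests on a few compounds, and the source may have more. Where it says the series, first, only, none or still open, it means among the compounds named here.

Of the compounds shown here, three built on one shared core have been measured in a physicochemical assay for acid dissociation. Compound 1 `CC(=O)NCc1cccc(Cn2nc(NS(=O)(=O)c3ccc(Cl)s3)c3c(F)cccc32)c1` gives 5.62, compound 2 `CC(=O)NCc1cccc(Cn2nc(NS(=O)(=O)c3ccc(Cl)s3)c3c(O)cccc32)c1` gives 6.12, and compound 3 `CC(=O)NCc1cccc(Cn2nc(NS(=O)(=O)c3ccc(Cl)s3)c3c(CO)cccc32)c1` gives 5.66. Compound 2 stands highest of the three: the step of a number 0.50 log units higher from compound 1 to compound 2 (beyond the scatter) and the step of a number 0.46 log units lower from compound 2 to compound 3 (beyond the scatter) are both beyond the scatter, whereas a number 0.04 log units higher from compound 1 to compound 3 (within the scatter). Compound 4 `CC(=O)NCc1cccc(Cn2nc(NS(=O)(=O)c3ccc(Cl)s3)c3c(C(F)F)cccc32)c1` differs from compound 2 in one place: difluoromethyl in place of hydroxy on an aromatic carbon. The two measured steps that involve the hydroxy group bear on this change, and both were modest in size. Because a number 0.50 log units higher from compound 1 to compound 2 (beyond the scatter) and a number 0.46 log units lower from compound 2 to compound 3 (beyond the scatter) both leave compound 2 as the higher partner, the expected step is a number 0.52 log units lower from compound 2 to compound 4 (beyond the scatter). Compound 4 is therefore estimated at 5.6, within 5.3 to 5.9.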

Compound 4, acid dissociation constant: 5.6
Compound 4: the middle estimate sits on the measured number at the digits printed; low and high end bracket the measured number.
By their numbers in this assay, from the lowest: compounds 4, 1 and 3 (each within the scatter of the next); then compound 2.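

In this assay, difluoromethyl in place of hydroxy gives a number 0.52 log units lower from compound 2 to compound 4 (beyond the scatter) and so joins the lower group. The steps of a number 0.06 log units lower from compound 3 to compound 4 (within the scatter) and a number 0.02 log units lower from compound 1 to compound 4 (within the scatter) leave difluoromethyl, hydroxymethyl and fluoro indistinguishable at this position, with hydroxy alone standing apart among the four groups. Nothing measured here explains the difference. Still open, from the compounds shown here alone, is whether methoxy, an amine or a carboxylic acid at this position would sit with hydroxy or with the other three groups.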